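A few compounds are considered here, and "the series" means these few. Any claim that something is new, unique, unknown or untested is made for them only; others in the source may bear on it.

Measured so far:
compound 1 `C=C(C)[C@H]1CC=C(C)[C@@]2(O)[C@@H]1[C@H](c1cccc(Cl)c1Cl)O[C@@H]2C(=O)OCC` — 5000 nM
compound 2 `C=C(C)[C@H]1CC=C(C)[C@@]2(O)[C@@H]1[C@H](c1ccccc1Br)O[C@@H]2C(=O)OCC1CCCC1` — > 100000 nM

In a functional assay on KB3 cells (Homo sapiens) for antiproliferative activity, read by MTT assay, with a stated time of 96 h (a lower number here means a stronger inhibitor, a higher number a weaker inhibitor), compound 1 gives 5000 nM. Compound 2 gives only a limit in this assay, > 100000 nM, so its true value is not known as a number. Compound 2 therefore stands at the limit of > 100000 nM in this assay, at which 1 of the 2 values shown sits, while compound 1 sits at a measured number well inside the range of this assay.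

Compound 3 `C=C(C)[C@H]1CC=C(C)[C@@]2(O)[C@@H]1[C@H](c1ccccc1Br)O[C@@H]2C(=O)OCC` differs from compound 2 in one place: methyl in place of cyclopentyl on a saturated chain carbon bound to an oxygen next to a carbonyl group. This brings the ester of compound 3 into line with that of compound 1. Among the compounds with values here, no step between two measured compounds is known here, so the size of the step is uncertain, but a move toward lower numbers in this assay is expected, since compound 1, with the same ester, gives 5000 nM. The step from compound 2 to compound 3 is estimated as an at least 8.3-fold lower number from compound 2 to compound 3 (0.92 log units; beyond the scatter). For compound 3 the expected value is 12000 nM, with a range from 3000 nM to 60000 nM.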

Compound 3, half-maximal inhibitory concentration: 20000 nM
Beside the measured number, compound 3's estimate is 1.7-fold (0.22 log units) below it; low and high end bracket the measured number.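

On a saturated chain carbon bound to an oxygen next to a carbonyl group, with the 2-bromophenyl group held fixed, replacing cyclopentyl with methyl gives an at least 5.0-fold lower number from compound 2 to compound 3 (0.69 log units; beyond the scatter) in this assay. This is the first step read at this place, and it is a bound rather than a full size, as compound 2 gives only a limit: the limit of > 100000 nM in this assay, at which 1 of the 3 values shown sits.

With the ethoxycarbonyl group held fixed, placing 2-bromophenyl instead of 2,3-dichlorophenyl on a saturated ring carbon gives a 4.0-fold higher number from compound 1 to compound 3 (0.60 log units; beyond the scatter), so the number responds to a change at this second place as well.

The compounds shown leave open how a longer chain, such as n-butyl, or a carboxylic acid would read at the ester. They also leave open whether the change from methyl to cyclopentyl would give a similar step alongside 2,3-dichlorophenyl.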